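The compounds below may be only part of what the source reports. "The series", "measured", "known", "first", "only" and "open" are said of these compounds alone.

In a functional assay on ECa-109 cells (Homo sapiens) for cytotoxicity, read by MTT assay, with a stated time of 72 h (a higher number here means a weaker inhibitor, a lower number a stronger inhibitor), compound 1 `COc1cccc(C=C2C(=O)N(c3ccc(Cl)cc3)N(c3ccc(Cl)cc3)C2=O)c1O` gives 39000 nM and compound 2 `COc1ccccc1C=C1C(=O)N(c2ccc(Cl)cc2)N(c2ccc(Cl)cc2)C1=O` gives 30400 nM. Among the measured compounds shown here, these are the only two numbers so far, and they stand level: the one measured step, a 1.3-fold lower number from compound 1 to compound 2 (0.11 log units; within the scatter), lies within the scatter of repeated measurements. Compound 3 `O=C1C(=Cc2ccc(Cl)cc2Cl)C(=O)N(c2ccc(Cl)cc2)N1c1ccc(Cl)cc1` keeps the shared core but carries 2,4-dichlorophenyl in place of 2-methoxyphenyl on a double-bonded chain carbon bound to a double-bonded ring carbon, as counted here: 2,4-dichlorophenyl in place of 2-methoxyphenyl on a double-bonded chain carbon bound to a double-bonded ring carbon. The measured step changed the group at this same place, and the number of compound 2 stayed within the scatter of compound 1. That is thin evidence, since the entering group has not been measured there. Even so, no step beyond the scatter is expected in this assay, and no direction is favoured. The estimated step is a 1.1-fold lower number from compound 2 to compound 3 (0.04 log units; within the scatter). Compound 3 is expected at 28000 nM, within an estimated range of 12000 nM to 65000 nM.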

Compound 3, half-maximal inhibitory concentration: 60200 nM
Compound 3: the middle estimate sits 2.2-fold (0.33 log units) below what was measured, within the range that was stated.
By their numbers in this assay, from the lowest: compounds 2, 1 and 3 (each within the scatter of the next).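

In this assay the change to 2,4-dichlorophenyl on a double-bonded chain carbon bound to a double-bonded ring carbon gives a 2.0-fold higher number from compound 2 to compound 3 (0.30 log units; within the scatter) and also a 1.5-fold higher number from compound 1 to compound 3 (0.19 log units; within the scatter) so neither step leaves the scatter. Compounds 1 and 2 carried only oxygen-bearing groups at this place, whereas compound 3 carries a ring with chlorine, no oxygen and no hydrogen-bond acceptor, and it still reads level with both. No further measurement shown here bears on this result.

The compounds shown leave open whether an amine or a carboxylic acid on the aromatic ring at this place would move the number beyond the scatter. They also leave open whether any group at this place can do so, since all three tested here read alike.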